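The source may hold more compounds than are shown below. What is called first, only, known or untested is meant among the compounds shown, and "the series" means these compounds.

Compound 1 `Cc1ccc2c(c1)/C(=C1/Nc3ccccc3/C1=N\O)C(=O)N2Cc1ccc(/C=C/C(=O)NO)cc1`: 50 nM
Compound 2 `O=C(/C=C/c1ccc(CN2C(=O)/C(=C3\Nc4ccccc4\C3=N/O)c3cc(Br)ccc32)cc1)NO`: 60 nM

These two compounds were tested in a functional assay on SW-620 cells (Homo sapiens) for cytotoxicity, read by colorimetric assay; on this read-out lower numbers stand for stronger inhibition and higher numbers for weaker inhibition. Among the compounds with values here, compound 2, at 60 nM, stands level with compound 1 within the scatter, and no other measured compound lies near it. Compound 3 `O=C(/C=C/c1ccc(CN2C(=O)/C(=C3\Nc4ccccc4\C3=N/O)c3cc(F)ccc32)cc1)NO` has not yet been measured. It carries fluoro in place of bromo on an aromatic carbon. Within the data shown here, only one measured step bears on this change: a 1.2-fold higher number from compound 1 to compound 2 (0.08 log units; within the scatter), with bromo in place of methyl on an aromatic carbon. Among the measured compounds shown here, no fluoro compound has been measured, so this evidence is indirect. Since that single step stayed small, no change beyond the scatter is expected in this assay. The expected step is a 1.1-fold lower number from compound 2 to compound 3 (0.04 log units; within the scatter). For compound 3 the estimated value is 55 nM, with an expected range from 25 nM to 120 nM.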

Compound 3, half-maximal inhibitory concentration: 50 nM
Compound 3: the middle estimate sits 1.1-fold (0.04 log units) above what was measured; the measured number falls inside the stated range.
By their numbers in this assay, from the lowest: compounds 1, 3 and 2 (each within the scatter of the next).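

In this assay, fluoro at this aromatic carbon reads level with both groups tested there before: swapping it for bromo gives a 1.2-fold lower number from compound 2 to compound 3 (0.08 log units; within the scatter), and swapping it for methyl gives no change at the digits printed from compound 1 to compound 3 (within the scatter). With a third group in place, the earlier single pair becomes a set of three in which every step stays within the scatter, so this read-out separates none of methyl, bromo and fluoro at this position. Nothing at hand bears on the reason for this flat result.

The compounds shown leave open whether the picture would hold with a larger or differently charged group here, such as an amine, a carboxylic acid or a methoxy group. They also leave open how plain hydrogen at this carbon would read in this assay.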